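The source may report more compounds than this note shows. Statements on the series, on what has been measured and on what is new or still open speak of the compounds shown alone.

Working notes on the series.

Compound 1 `CC(=O)Nc1c(C(O)(C(F)(F)F)C(F)(F)F)ccc2ccccc12` carries a methyl on the carbonyl carbon of the amide and gives 18 nM in an assay on LtK cells with ATP-sensitive inward rectifier potassium channel 11 (Homo sapiens) as the target; on this read-out higher numbers stand for an effect only at larger amounts of compound and lower numbers for an effect already at smaller amounts. Compound 2 `Cc1ccccc1C(=O)Nc1c(C(O)(C(F)(F)F)C(F)(F)F)ccc2ccccc12` gives 5550 nM, and compound 3 `Cc1cccc(C(=O)Nc2c(C(O)(C(F)(F)F)C(F)(F)F)ccc3ccccc23)c1` gives 23 nM. Compound 3 thus stands second highest of the three numbers: its nearest neighbour is compound 1, with a 1.3-fold higher number from compound 1 to compound 3 (0.11 log units; within the scatter) within the scatter, and its furthest is compound 2, with a 240-fold lower number from compound 2 to compound 3 (2.38 log units; beyond the scatter). The step of a 310-fold higher number from compound 1 to compound 2 (2.49 log units; beyond the scatter) shows the same contrast from the other side.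

Compound 4 `COc1ccc(C(=O)Nc2c(C(O)(C(F)(F)F)C(F)(F)F)ccc3ccccc23)cc1` is not yet measured. The change from compound 3 is 4-methoxyphenyl in place of 3-methylphenyl on a carbonyl carbon. The measured steps bear on it only in part: a 240-fold lower number from compound 2 to compound 3 (2.38 log units; beyond the scatter) shows that moving a methyl on the phenyl can shift this assay by a very large amount, while a 1.3-fold higher number from compound 1 to compound 3 (0.11 log units; within the scatter) shows that 3-methylphenyl sits level with methyl. Among the compounds with values here, no compound with a 4-methoxyphenyl, or with any group at that place on the phenyl, has been measured, so the direction of a 1.7-fold higher number from compound 3 to compound 4 (0.24 log units; within the scatter) is uncertain and a wide range is expected. On balance a number near that of compound 3 is estimated for compound 4, 40 nM, with a range from 8 nM to 600 nM.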

Compound 4, half-maximal effective concentration: 417 nM
Beside the measured number, compound 4's estimate is 10-fold (1.02 log units) below it, and the stated range covers the measured number.
By their numbers in this assay, from the lowest: compounds 1 and 3 (each within the scatter of the next); then compound 4; then compound 2.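

The result shows that the group on the carbonyl carbon does not tolerate every phenyl with only a small shift in this assay: an 18-fold higher number from compound 3 to compound 4 (1.26 log units; beyond the scatter), and a 23-fold higher number from compound 1 to compound 4 (1.36 log units; beyond the scatter), so the level position of 3-methylphenyl and methyl does not extend to 4-methoxyphenyl. At the same time, a 13-fold lower number from compound 2 to compound 4 (1.12 log units; beyond the scatter), which places the 4-methoxyphenyl amide in the middle of the series and shows that the three phenyl amides spread over distinct levels, with only compound 3 staying within the scatter of compound 1. No measurement at hand accounts for these steps.

Compound 3 and compound 4 differ both in the group on the phenyl and in where it sits, and the compounds shown do not separate these two changes. Still open, going by these compounds, is how far the number would move with a methoxy at the place of the methyl of compound 3, with a methyl at the place of the methoxy of compound 4, or with another group at either place, such as a chlorine, an amine or a carboxylic acid.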